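Swapping the aryl group on the hydrazone carbon

The source may report more compounds than this note shows. Statements on the series, on what has been measured and on what is new or still open speak of the compounds shown alone.

Of the compounds shown here, three sharing one core have been tested in a functional assay on MKN-45 cells (Homo sapiens) for cytotoxicity, read by MTT assay, with a stated time of 72 h; a higher number here means a weaker inhibitor, a lower number a stronger inhibitor. Compound 1 `CN(C)CCn1cnnc1-c1cc(Oc2ccc(NC(=O)N/N=C/c3cc(C(C)(C)C)cc(C(C)(C)C)c3O)cc2F)ccn1` gives 3300 nM. Compound 2 `COc1ccc(/C=N/NC(=O)Nc2ccc(Oc3ccnc(-c4nncn4CCN(C)C)c3)c(F)c2)c(OC)c1OC` gives 2020 nM. Compound 3 `CN(C)CCn1cnnc1-c1cc(Oc2ccc(NC(=O)N/N=C/c3ccccc3O[N+](=O)[O-])cc2F)ccn1` gives 1020 nM; compound 2 lies within the scatter of this number, while compound 1 lies beyond it. For the measured compounds named here, the one step between neighbours that differ in a single place is a 2.0-fold lower number from compound 2 to compound 3 (0.30 log units; within the scatter), a change at the very position considered next.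

Compound 4 `CN(C)CCn1cnnc1-c1cc(Oc2ccc(NC(=O)N/N=C/c3ccc(O)c(O)c3)cc2F)ccn1` is built from compound 3 by the change (3,4-dihydroxyphenyl in place of 2-(nitrooxy)phenyl on a carbon with a double bond to nitrogen). Going by the values given here, both groups that have been tried so far at this position gave numbers within the scatter of each other, so the only step that bears on this change, from compound 2 to compound 3, was small. Among the compounds with values here, on that basis no shift beyond the scatter is expected in this assay, though with only one relevant step the uncertainty is wide. The expected result for compound 4 is 1500 nM, with a range from 500 nM to 5000 nM. In terms of the step, compound 4 is estimated to differ from compound 3 by a 1.5-fold higher number from compound 3 to compound 4 (0.17 log units; within the scatter).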

Compound 4, half-maximal inhibitory concentration: 3240 nM
The estimate for compound 4 lay 2.2-fold (0.33 log units) below the measured number; low and high end bracket the measured number.
By their numbers in this assay, from the lowest: compounds 3, 2, 4 and 1 (each within the scatter of the next, the first and the last beyond it).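

This position does respond to the group placed on it: in this assay, 3,4-dihydroxyphenyl in place of 2-(nitrooxy)phenyl gives (a 3.2-fold higher number from compound 3 to compound 4 (0.50 log units; beyond the scatter)), a modest step, but the first at this position to lie beyond the scatter. For the compounds shown here, the other step gives (a 1.6-fold higher number from compound 2 to compound 4 (0.21 log units; within the scatter)), so 3,4-dihydroxyphenyl and 2,3,4-trimethoxyphenyl cannot be told apart here, and 2,3,4-trimethoxyphenyl also stays within the scatter of 2-(nitrooxy)phenyl; of these three groups, only the pair in compound 3 and compound 4 is separated. Nothing measured here explains why that pair differs.

Going by these compounds, it remains open whether the separation depends on the nitrooxy group itself or whether other groups on the ring would give a similar number. A plain phenyl ring would provide a simple point of comparison for all three groups, while a phenyl ring carrying an amine or a carboxylic acid would show how far the numbers at this position can move in either direction.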